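Adding a Carbamoyl Group to the Oxazole Substituent

This account rests on a few compounds, and the source may have more. Where it says the series, first, only, none or still open, it means among the compounds named here.

Of the compounds shown here, three have been measured in an assay for inhibition of Fatty-acid amide hydrolase 1 (Rattus norvegicus); on this read-out higher numbers stand for weaker inhibition and lower numbers for stronger inhibition. Compound 2 `O=C(CCc1ccc(-c2ccccc2)cc1)c1ncc(-c2cccnc2)o1` gives 1.1 nM. This is the lowest of the three numbers. Compound 1 `CNC(=O)c1cnc(C(=O)CCc2ccc(COc3ccccc3)cc2)o1` gives 3.6 nM, a number higher than that of compound 2 by more than the usual scatter. Compound 3 `NC(=O)c1ccc(-c2cnc(CCCc3ccc(-c4ccccc4)cc3)o2)nc1` gives 30000 nM, far higher than the other two. Compound 3 differs from compound 2 in more than one place, so its weak result cannot be tied to any single change.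

The compound now to be measured is compound 4 `NC(=O)c1ccc(-c2cnc(C(=O)CCc3ccc(-c4ccccc4)cc3)o2)nc1`, which differs from compound 2 in one place only: 5-carbamoylpyridin-2-yl in place of pyridin-3-yl on an aromatic carbon. The ketone link to the side chain, shared by compound 1 and compound 2, stays in place. Among the compounds with values here, no measured pair shows this exact change, so its effect is not known from these data. Since compound 1, which carries a related amide group on the core, still gives 3.6 nM, a strong result for compound 4 seems plausible. The step of a 1.4-fold higher number from compound 2 to compound 4 (0.13 log units; within the scatter) is expected to be small, possibly none beyond the scatter, in either direction. Compound 4 is estimated at 1.5 nM, with a range from 0.4 nM to 6 nM.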

Compound 4, inhibition constant: 1.3 nM
Beside the measured number, compound 4's estimate is 1.2-fold (0.06 log units) above it; the measured number falls inside the stated range.
By their numbers in this assay, from the lowest: compounds 2 and 4 (each within the scatter of the next); then compound 1; then compound 3.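

In this assay, putting 5-carbamoylpyridin-2-yl in place of pyridin-3-yl on the aromatic carbon next to the ring oxygen gives a 1.2-fold higher number from compound 2 to compound 4 (0.07 log units; within the scatter), so this position takes a group with more heavy atoms and a hydrogen-bond donor with no change that can be told from the scatter. Compound 3 carries the same 5-carbamoylpyridin-2-yl group and gives 30000 nM, while compound 4 gives 1.3 nM, so that group alone cannot account for the weak number of compound 3; the two differ in the link to the side chain, where only compound 4 has the ketone. Nothing measured here bears on the reason for this result.

This step joins two changes, the switch from a pyridin-3-yl to a pyridin-2-yl attachment and the added carbamoyl group, so the compounds shown cannot separate what each does alone. Also open, from the compounds shown here alone, is whether a carboxylic acid or an amine in place of the carbamoyl group, or a plain phenyl ring at this same place, would keep a number of this size in this assay.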